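Removing one fluorine from the benzyloxy arm

The source may hold more compounds than are shown below. What is called first, only, known or untested is meant among the compounds shown, and "the series" means these compounds.

Among the measured compounds shown here, compound 1 `O=C(Nc1ccccc1F)Nc1cc2ncncc2cc1OCc1cccc(F)c1` sits at the higher end of the two numbers so far: in a functional assay on GBM1 cells (Homo sapiens) for antiproliferative activity, read by WST assay, with a stated time of 72 h (a higher number here means a weaker inhibitor, a lower number a stronger inhibitor), compound 1 gives 8000 nM. For the measured compounds named here, the only other measured member, compound 2 `O=C(Nc1ccc(Cl)c(Cl)c1)Nc1cc2ncncc2cc1OCc1cccc(F)c1`, gives 2100 nM, and the step of a 3.8-fold lower number from compound 1 to compound 2 (0.58 log units; beyond the scatter) came from exchanging the aryl group on the urea nitrogen, a part of the molecule untouched here.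

Compound 3 `O=C(Nc1ccccc1F)Nc1cc2ncncc2cc1OCc1ccccc1` differs from compound 1 at the other end, by hydrogen in place of fluoro on an aromatic carbon, so that the (3-fluorobenzyl)oxy group becomes a benzyloxy group. Going by the values given here, no measured pair tests this particular change; the single step known concerns a different position and therefore gives no direct guidance, and neither direction can be argued from the data.

Lacking any bearing evidence, the sensible expectation is that compound 3 remains close to compound 1, with a step of no change at the digits printed from compound 1 to compound 3 (within the scatter) that falls inside the usual scatter. Compound 3 is thus estimated at 8000 nM, with a range from 3000 nM to 20000 nM.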

Compound 3, half-maximal inhibitory concentration: 6100 nM
Compound 3: the middle estimate sits 1.3-fold (0.12 log units) above what was measured; the range from low to high includes it.
By their numbers in this assay, from the lowest: compound 2; then compounds 3 and 1 (each within the scatter of the next).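

In this assay the exchange of fluoro for hydrogen on the benzyl ring gives a 1.3-fold lower number from compound 1 to compound 3 (0.12 log units; within the scatter), so the fluorine on this aromatic carbon of the (3-fluorobenzyl)oxy group can be removed without a change that stands out from the ordinary spread of repeated measurements. Among the compounds shown here, this is the first reading at this end of the molecule, and it contrasts with the exchange at the other end, on the amide-type nitrogen, where 3,4-dichlorophenyl in place of 2-fluorophenyl gives a 3.8-fold lower number from compound 1 to compound 2 (0.58 log units; beyond the scatter) and the difference lies beyond the scatter. Nothing available explains why the fluorine makes so little difference here, and no separate measurement bears on the question.

The compounds shown leave open whether a larger or differently built group on this aromatic carbon, such as a methoxy group, an amine or a carboxylic acid, would also leave the number in place, since fluoro and hydrogen are the only two cases at hand. They also leave open whether the same exchange of fluoro for hydrogen would read the same in compound 2, which carries the 3,4-dichlorophenyl group.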